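This account rests on a few compounds, and the source may have more. Where it says the series, first, only, none or still open, it means among the compounds named here.

Compound 1 `CCCCNc1nc(N)nc2ccn(Cc3cccnc3)c12`: > 24000 nM
Compound 2 `CCOCCNc1nc(N)nc2ccn(Cc3ccccn3)c12`: > 24000 nM

Both compounds were tested in an ADME assay on HEK293 cells (Homo sapiens) for cytotoxicity, read by ATP content, with a stated time of 6 h; on this read-out lower numbers stand for higher toxicity in this test and higher numbers for lower toxicity in this test. In this assay compound 1 gives > 24000 nM, which is a limit of the assay and not a number. Compound 2 gives > 24000 nM, which is also a limit and not a number. Compound 2 therefore has no exact value and stands with compound 1 at the limit of > 24000 nM in this assay, at which 2 of the 2 values shown sit.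

Compound 3 `Nc1nc(NCc2ncco2)c2c(ccn2Cc2ccccn2)n1` has not yet been measured. It differs from compound 2 in one place: 1,3-oxazol-2-yl in place of ethoxymethyl on a saturated chain carbon bound to a nitrogen on an aromatic ring. In words, 1,3-oxazol-2-yl stands in place of ethoxymethyl on a saturated chain carbon bound to a nitrogen on an aromatic ring.

Among the measured compounds shown here, no measured pair shows what a single change does in this assay, so no direction can be predicted, and no step beyond the usual scatter is expected. This expectation rests on compound 2, whose > 24000 nM is a limit. The expected step is a step that the limit leaves unreadable from compound 2 to compound 3. Compound 3 may well be reported only as a limit too. For compound 3 the estimated value is 26000 nM, with an expected range of 12000 nM to 50000 nM.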

Compound 3, half-maximal cytotoxic concentration: > 24000 nM
Compound 3 was reported as a limit; the forecaster's own chance of this, stated with the estimate: 85%; the middle value is on the limit's open side.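

In this assay compound 3 gives > 24000 nM, which is a limit of the assay and not a number. Compound 2 also stands at a limit, so no step can be read from compound 2 to compound 3. The compounds shown leave open whether 1,3-oxazol-2-yl in place of ethoxymethyl, or any other single change, alters this read-out at all: the limit of > 24000 nM in this assay, at which 3 of the 3 values shown sit.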